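The source may report more compounds than this note shows. Statements on the series, on what has been measured and on what is new or still open speak of the compounds shown alone.

Three compounds have been measured in a functional assay on Ehrlich cells (Mus musculus) for cytotoxicity, read by trypan blue exclusion, with a stated time of 2 h, tested at 100 ug/mL; on this read-out lower numbers stand for a weaker effect and higher numbers for a stronger effect at the one concentration tested:

Compound 1 `N#CC1=C(N)N(c2ccc(S(N)(=O)=O)cc2)C2=C(CCCC2)C1c1ccccc1O`: 100%
Compound 2 `N#CC1=C(N)N(c2ccc(S(N)(=O)=O)cc2)C2=C(CCCC2)C1c1ccc(O)cc1`: 100%
Compound 3 `N#CC1=C(N)N(c2ccc(S(N)(=O)=O)cc2)C2=C(CCCC2)C1c1ccc(Cl)cc1Cl`: 70%

Compound 3 stands lowest of the three: a number 30 percentage points lower from compound 1 to compound 3 (beyond the scatter) and a number 30 percentage points lower from compound 2 to compound 3 (beyond the scatter), both beyond the scatter, while no change at the digits printed from compound 1 to compound 2 (within the scatter). The next compound, compound 4 `N#CC1=C(N)N(c2ccc(S(N)(=O)=O)cc2)C2=C(CCCC2)C1c1ccc(Cl)c(Cl)c1`, is not yet measured. It differs from compound 3 only in the aryl group on the saturated ring carbon: 3,4-dichlorophenyl in place of 2,4-dichlorophenyl on a saturated ring carbon.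

For the measured compounds named here, no measured step bears directly on this change. The two steps that reach compound 3 both replace a hydroxyphenyl group by the 2,4-dichlorophenyl group, and each moves the read-out in this assay by a modest amount. Going by the values given here, nothing among the measured compounds shows what moving one chlorine from one ring position to another does; the two hydroxyphenyl compounds, compound 1 and compound 2, differ in the ring position of their hydroxyl and show no change within the scatter, which is the only hint of that kind. On this basis the step of no change at the digits printed from compound 3 to compound 4 (within the scatter) is expected to stay within the scatter. Compound 4 is therefore estimated at 70% in this assay, with a range from 45% to 95%.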

Compound 4, a percentage reported as activity, at one concentration (the size of the read-out at that concentration, not a potency): 50%
Compound 4: the middle estimate sits 20 percentage points above what was measured, within the range that was stated.
By their numbers in this assay, from the lowest: compound 4; then compound 3; then compounds 1 and 2 (each within the scatter of the next).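

In this assay, exchanging one dichlorophenyl pattern for the other on the saturated ring carbon is not a silent change: the two groups have the same atoms and the same counts, yet 3,4-dichlorophenyl in place of 2,4-dichlorophenyl gives a number 20 percentage points lower from compound 3 to compound 4 (beyond the scatter) and thus shows that the two dichlorophenyl compounds do not share one level, unlike the hydroxyphenyl pair, which shows no change at the digits printed from compound 1 to compound 2 (within the scatter). Set against the hydroxyphenyl compounds, the 3,4-dichlorophenyl group goes further than the 2,4-dichlorophenyl group did, with a number 50 percentage points lower from compound 2 to compound 4 (beyond the scatter) and a number 50 percentage points lower from compound 1 to compound 4 (beyond the scatter), so at this position the read-out depends on where the chlorines stand as well as on which atoms are present. Nothing available here explains why the arrangement of the chlorines changes the read-out.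

As far as these compounds go, whether a single chlorine, as in 4-chlorophenyl, or a different pair of atoms, as in 3,4-dimethoxyphenyl or 3,4-difluorophenyl, would stand with the dichlorophenyl compounds or with the hydroxyphenyl compounds remains open. Since every value comes from one concentration, the compounds shown also leave open how the order would look at lower concentrations.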